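A few compounds are considered here, and "the series" means these few. Any claim that something is new, unique, unknown or untested is made for them only; others in the source may bear on it.

Three analogues sharing one core have been measured in an assay on isolated protein for inhibition of Amine oxidase [flavin-containing] A (Homo sapiens), read by spectrophotometry; a higher number here means a weaker inhibitor, a lower number a stronger inhibitor. Compound 1 `COc1cc(/C(C)=N/Nc2nc3ccccc3nc2Cc2ccccc2)cc(OC)c1OC` gives 29 nM. Compound 2 `Clc1ccc(/C=N/Nc2nc3ccccc3nc2Cc2ccccc2)cc1` gives 76 nM, and compound 3 `C/C(=N\Nc1nc2ccccc2nc1Cc1ccccc1)c1ccccc1` gives 79 nM. Among these three numbers compound 2 holds the second highest; its nearest neighbour is compound 3, since a 1.0-fold higher number from compound 2 to compound 3 (0.02 log units; within the scatter), whereas compound 1 sits a clear distance lower. Within the data shown here, no single-point step connects compound 1 with compound 2, so only their two values can be set side by side.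

Compound 4 `CN(C)c1ccc(/C=N/Nc2nc3ccccc3nc2Cc2ccccc2)cc1` has not yet been measured. It differs from compound 2 in one place: dimethylamino in place of chloro on an aromatic carbon. Among the measured compounds shown here, only one measured step touches the same ring: a 1.0-fold higher number from compound 2 to compound 3 (0.02 log units; within the scatter), an exchange of the whole aryl group together with the substituent on the imine carbon that left the number essentially where it was. That step suggests a change on this ring need not move the number much, although it is not the same exchange, and compound 1 shows that a more heavily substituted ring can go with a lower number. The expectation for compound 4 is therefore a small step, a 1.3-fold lower number from compound 2 to compound 4 (0.10 log units; within the scatter), of uncertain direction. Compound 4 is expected to give 60 nM, with a range from 20 nM to 200 nM.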

Compound 4, half-maximal inhibitory concentration: 83 nM
Compound 4: the middle estimate sits 1.4-fold (0.14 log units) below what was measured; the measured number falls inside the stated range.
By their numbers in this assay, from the lowest: compound 1; then compounds 2, 3 and 4 (each within the scatter of the next).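

In this assay, the exchange of chloro for dimethylamino on an aromatic carbon, para to a large group, gives a 1.1-fold higher number from compound 2 to compound 4 (0.04 log units; within the scatter) and so leaves compound 2 and compound 4 indistinguishable. Among these compounds, this is the first step confined to the single substituent on this ring, whereas the earlier step from compound 2 to compound 3 also altered the imine carbon, so the flat result can now be tied to this position alone. Dimethylamino brings more heavy atoms and a hydrogen-bond acceptor that chloro lacks, yet the number in this assay stays within the scatter, and no measurement shown explains this result.

Among the compounds shown here, whether a carboxylic acid or a primary amine at this same place would also leave the number within the scatter remains open, since these two substituents are the only pair compared here. For the compounds shown here, it also remains open which feature goes with the lower number of the series, as compound 1 at 29 nM is joined to the others by no single-place step.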